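Bromine for Fluorine on the Pendant Phenyl Ring

The source may report more compounds than this note shows. Statements on the series, on what has been measured and on what is new or still open speak of the compounds shown alone.

Three amides built on one shared core have been measured in a functional assay on A549 cells (Homo sapiens) for cytotoxicity, read by MTT assay, with a stated time of 72 h; a lower number here means a stronger inhibitor, a higher number a weaker inhibitor. Compound 1 `COc1ccc(-c2ccnc(C(=O)Nc3ccc(Oc4ccnc5[nH]ccc45)cc3)n2)cc1` gives 13300 nM. Compound 2 `O=C(Nc1ccc(Oc2ccnc3[nH]ccc23)cc1)c1cc(-c2ccc(F)cc2)ncn1` gives 13000 nM. Compound 3 `O=C(Nc1ccc(Oc2ccnc3[nH]ccc23)c(F)c1)c1cc(-c2ccc(F)cc2)ncn1` differs from compound 2 by fluoro in place of hydrogen on an aromatic carbon. Compound 3 gives 14200 nM. Among the measured compounds shown here, the one single-point step among them, a 1.1-fold higher number from compound 2 to compound 3 (0.04 log units; within the scatter), lies within the scatter, and the numbers of compound 3 and compound 1 also sit within the scatter of each other, so none of the three can be set above or below another on these data.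

Compound 4 `O=C(Nc1ccc(Oc2ccnc3[nH]ccc23)c(F)c1)c1cc(-c2ccc(Br)cc2)ncn1` differs from compound 3 in one place: bromo in place of fluoro on an aromatic carbon, on an aromatic carbon of a six-membered aromatic ring of carbon only, para to a large group; cut one bond further out, the change reads 4-fluorophenyl to 4-bromophenyl. For the measured compounds named here, no measured step exchanges one halogen for another anywhere in this set, so the expectation rests on the general flatness of the numbers. Compound 4 is expected to show a step of a 1.1-fold lower number from compound 3 to compound 4 (0.04 log units; within the scatter) in this assay, none beyond the scatter, because compound 2 gives 13000 nM and compound 1 gives 13300 nM despite their different pendant groups. The estimate for compound 4 is 13000 nM, with a range from 5500 nM to 31000 nM.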

Compound 4, half-maximal inhibitory concentration: 6980 nM
Compound 4: middle estimate off by 1.9-fold (0.27 log units), on the high side; low and high end bracket the measured number.
By their numbers in this assay, from the lowest: compounds 4, 2, 1 and 3 (each within the scatter of the next, the first and the last beyond it).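

In this assay, among the compounds shown here, the change from 4-fluorophenyl to 4-bromophenyl gives a 2.0-fold lower number from compound 3 to compound 4 (0.31 log units; beyond the scatter) and so is the first step in this set to pass beyond the scatter, though only modestly. For the compounds shown here, the sole earlier step, a 1.1-fold higher number from compound 2 to compound 3 (0.04 log units; within the scatter), stayed within the scatter, so this position, on an aromatic carbon of a six-membered aromatic ring of carbon only and para to a large group, is the first place where exchanging one atom for another moves the number at all, and the flatness of the first three compounds does not extend to it. Nothing available accounts for this step.

Going by these compounds, whether the number follows the halogens in turn or answers to bromo alone stays open, and chloro or iodo at this place would separate the two, while a methyl group or an amine there would show whether a non-halogen can do the same. A bromo partner of compound 2 would further tell whether the step holds without the extra fluoro that compound 3 carries.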